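Chloro to cyano: a small swap on a limited reading

A few compounds are considered here, and "the series" means these few. Any claim that something is new, unique, unknown or untested is made for them only; others in the source may bear on it.

In an ADME assay on L02 cells (Homo sapiens) for cytotoxicity, read by MTT assay, with a stated time of 24 h (a higher number here means a weaker inhibitor, a lower number a stronger inhibitor), compound 1 (`CN1C/C(=C\c2cccnc2)C(=O)/C(=C/c2ccccc2F)C1`) gives 15900 nM as its reading, and compound 2 (`Cc1ccc(S(=O)(=O)N2C/C(=C\c3cccnc3)C(=O)/C(=C/c3ccccc3F)C2)cc1`) gives 14900 nM on the same scale. Placing (4-methylphenyl)sulfonyl where methyl sat on the amine nitrogen in the ring gives a 1.1-fold lower number from compound 1 to compound 2 (0.03 log units; within the scatter) as the measured step. Compound 3 (`O=C1/C(=C/c2cccnc2)CN(S(=O)(=O)c2ccc(Cl)cc2)C/C1=C\c1ccccc1F`) gives > 20000 nM in this assay and this is a limit, not a number. The steps that reach it are an at least 1.2-fold higher number from compound 1 to compound 3 (0.09 log units; that floor lies within the scatter) for (4-chlorophenyl)sulfonyl in place of methyl, and an at least 1.3-fold higher number from compound 2 to compound 3 (0.12 log units; that floor lies within the scatter) for chloro in place of methyl on an aromatic carbon.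

Compound 4 (`N#Cc1ccc(S(=O)(=O)N2C/C(=C\c3cccnc3)C(=O)/C(=C/c3ccccc3F)C2)cc1`) has cyano in place of chloro on an aromatic carbon, para to a large group, and the counted change is cyano in place of chloro on an aromatic carbon in full. The closest guide is the swap on that same aromatic carbon, an at least 1.3-fold higher number from compound 2 to compound 3 (0.12 log units; that floor lies within the scatter) as measured, and no change at the sulfonyl substituent has yet gone beyond the scatter. A step beyond the scatter is therefore not expected, and the expected step is an at least 1.1-fold lower number from compound 3 to compound 4 (0.07 log units; that floor lies within the scatter) in this assay on this reasoning. The estimate for compound 4 is 17000 nM within an expected range of 9000 nM to 30000 nM overall.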

Compound 4, half-maximal inhibitory concentration: > 20000 nM
Compound 4: only a limit was reported (the forecaster's own chance of this, stated with the estimate: 40%); middle value at least 1.1-fold (0.07 log units) from the limit.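

In this assay compound 4 reads > 20000 nM, which is a limit and not a number. Cyano is now the second group, after chloro, on this aromatic carbon para to a large group to give a limit rather than a number, and the readable comparisons are an at least 1.3-fold higher number from compound 2 to compound 4 (0.12 log units; that floor lies within the scatter) for cyano in place of methyl on that carbon, and an at least 1.2-fold higher number from compound 1 to compound 4 (0.09 log units; that floor lies within the scatter) for the whole (4-cyanophenyl)sulfonyl in place of methyl on the ring nitrogen, so neither floor shows a change beyond the scatter. The direct swap of chloro for cyano cannot be read, because compound 3 and compound 4 both stop at the same ceiling: the limit of > 20000 nM in this assay, at which 2 of the 4 values shown sit.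

On these data alone, how far compound 3 and compound 4 each lie past that limit stays unknown, so cyano and chloro cannot be ranked against each other at this carbon. Also open, as far as these compounds go, is whether a different group on the same carbon, such as an amine or a carboxylic acid, would give a true number in this assay and move it beyond the scatter from compound 2.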